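Working notes on compound 3 in the agonist series

The source may hold more compounds than are shown below. What is called first, only, known or untested is meant among the compounds shown, and "the series" means these compounds.

Measured compounds:
compound 1 `COc1ccc(F)c(-c2ccc(S(=O)(=O)Nc3cc(N4C[C@@H](C)N[C@@H](C)C4)ccc3OC)cc2)c1`: 0.398 nM
compound 2 `COc1ccc(N2C[C@@H](C)N[C@@H](C)C2)cc1NS(=O)(=O)c1ccc(-c2cnco2)s1`: 2.51 nM

Two compounds have numbers in a functional assay for agonist activity at growth hormone secretagogue receptor type 1 (Homo sapiens), read by FLIPR; a higher number here means that more compound is needed for the effect, a lower number that less compound is needed. Compound 1 gives 0.398 nM and stands lowest of the two; compound 2, the nearest, gives 2.51 nM, a gap that lies beyond the usual scatter. Among the compounds with values here, no step between two measured compounds that differ in one place is available, so the following expectation rests only on these two values and on the structural change itself.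

Compound 3 `COc1ccc(N2C[C@@H](C)N[C@@H](C)C2)cc1NS(=O)(=O)c1ccc(OCc2ccccc2)cc1` is unmeasured. It differs from compound 1 in one place: benzyloxy in place of 2-fluoro-5-methoxyphenyl on an aromatic carbon. The group that leaves carries a fluorine and a methoxy on its ring; the group that enters is a benzyloxy, linked through an oxygen. Nothing in the two values shown fixes the size of such a step, so an estimate of moderate loss is taken as the expectation, since compound 1 sits at the low end and compound 2 shows the series tolerating other groups at a higher number. The step is expected as a 5.0-fold higher number from compound 1 to compound 3 (0.70 log units; beyond the scatter), upward. For compound 3 in this assay a value of 2 nM is estimated, within 0.5 nM to 8 nM.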

Compound 3, half-maximal effective concentration: 100 nM
The estimate for compound 3 lay 50-fold (1.70 log units) below the measured number; measured number outside the range, above it.
By their numbers in this assay, from the lowest: compound 1; then compound 2; then compound 3.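

In this assay, benzyloxy in place of 2-fluoro-5-methoxyphenyl on this aromatic carbon, para to a large group, gives a 250-fold higher number from compound 1 to compound 3 (2.40 log units; beyond the scatter), so this position is far from indifferent to the group it carries. The change looks small by simple counts: each group has one six-membered aromatic ring of carbon only, 0 hydrogen-bond donors, 1 hydrogen-bond acceptor and no net charge, with 9 heavy atoms leaving and 8 entering, so these counts do not track the size of the step. No measurement bears on what lies behind the step, and no feature of the change can be assigned to it.

The change alters the link to the ring and the ring's substituents together, leaving open whether the oxygen link, the loss of the fluorine or the loss of the methoxy accounts for the step. Plain phenyl, 2-fluorophenyl, 3-methoxyphenyl or a phenethyl chain at this place would separate those parts on the core of compound 1.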